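Fluoro to methyl on the aroyl amide of compound 2

The compounds below may be only part of what the source reports. "The series", "measured", "known", "first", "only" and "open" are said of these compounds alone.

Compound 2 `O=C(CSc1cccc(O)c1)Nc1ccc2nc(NC(=O)c3ccc(F)cc3)sc2c1` is the lower of the two numbers in a functional assay on HCT-116 cells (Homo sapiens) for antiproliferative activity, read by MTT assay, with a stated time of 72 h (a lower number here means a stronger inhibitor, a higher number a weaker inhibitor), where compound 2 gives 6170 nM. Compound 1 `CCCC(=O)Nc1nc2ccc(NC(=O)CSc3cccc(O)c3)cc2s1` sits nearest, with compound 1 giving 10600 nM, and the step of a 1.7-fold lower number from compound 1 to compound 2 (0.24 log units; within the scatter) is within the scatter. Compound 3 `O=C(CSc1nnc(NC(=O)COc2ccccc2)s1)Nc1ccc(Br)cc1` reaches only a limit of this assay, compound 3 giving > 100000 nM; this is the limit of > 100000 nM in this assay, at which 1 of the 3 values shown sits. Compound 4 `Cc1ccc(C(=O)Nc2nc3ccc(NC(=O)CSc4cccc(O)c4)cc3s2)cc1` differs from compound 2 by methyl in place of fluoro on an aromatic carbon. Among the compounds with values here, no measured step changes a substituent on that ring; the one step from compound 1 to compound 2 exchanged the whole acyl group and stayed within the scatter. A step of about a 1.1-fold higher number from compound 2 to compound 4 (0.02 log units; within the scatter) is therefore expected, no more than scatter. Compound 4 is estimated at 6500 nM, between 3000 nM and 15000 nM.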

Compound 4, half-maximal inhibitory concentration: 7730 nM
Compound 4: the middle estimate sits 1.2-fold (0.08 log units) below what was measured; the range from low to high includes it.
By their numbers in this assay, from the lowest: compounds 2, 4 and 1 (each within the scatter of the next). At a limit, above all of these: compound 3.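

In this assay, within the data shown here, methyl in place of fluoro on the aromatic carbon para to a large group gives a 1.3-fold higher number from compound 2 to compound 4 (0.10 log units; within the scatter), the first measured change of a single substituent on this ring, and it does not separate the two groups. The 4-methylphenyl group in place of propyl gives a 1.4-fold lower number from compound 1 to compound 4 (0.14 log units; within the scatter), so this second aroyl group likewise shows no step beyond the scatter. Nothing available bears on this result. As far as these compounds go, whether an amine or a carboxylic acid at this ring position would move the number beyond the scatter remains open.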